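A few compounds are considered here, and "the series" means these few. Any claim that something is new, unique, unknown or untested is made for them only; others in the source may bear on it.

Of the compounds shown here, three have so far been tested in an assay on membranes from HEK293 cells for displacement of a labelled ligand from adenosine receptor A2b (Homo sapiens), read by scintillation counting, with a stated time of 30 min, tested at 1 uM; on this read-out lower numbers stand for less inhibition and higher numbers for more inhibition at the one concentration tested (going by the name of the read-out). Compound 1 `CCCOC(=O)C1=C(C)NC(=S)NC1c1cccs1` gives 3% and compound 2 `CCCOC(=O)C1=C(C)N(C)C(=O)NC1c1cccs1` gives 1%. Compound 3 `CC(=O)C1=C(C)NC(=O)NC1c1ccoc1` gives 15%, the highest of the three numbers, separated from compound 1 by a gap beyond the usual scatter and from compound 2 by a slightly wider gap, also beyond the scatter. For the measured compounds named here, none of these three compounds differs from another in one place only, so no single step between measured compounds is known.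

Compound 4 `CCCC(=O)C1=C(C)NC(=O)NC1c1ccoc1` has not yet been measured in this assay. It differs from compound 3 by ethyl in place of hydrogen on a saturated chain carbon bound to a carbonyl carbon. Going by the values given here, nothing among the measured compounds shows what such a change does in this assay. The step of no change at the digits printed from compound 3 to compound 4 (within the scatter) is therefore expected to be small, no wider than the scatter, in either direction. On that basis the inhibition of compound 4 is estimated at 15%, with a range from 3% to 30%.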

Compound 4, a percentage reported as inhibition, at one concentration (the size of the read-out at that concentration, not a potency): 22%
The estimate for compound 4 lay 7 percentage points below the measured number, and the stated range covers the measured number.
By their numbers in this assay, from the lowest: compounds 2 and 1 (each within the scatter of the next); then compounds 3 and 4 (each within the scatter of the next).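

Ethyl in place of hydrogen on a saturated chain carbon bound to a carbonyl carbon, which turns acetyl into propylcarbonyl, gives the only single-place step known so far in this assay, namely a number 7 percentage points higher from compound 3 to compound 4 (within the scatter), and this step lies within the usual scatter. This position therefore accepts the added ethyl without a shift that can be told apart from repeat variation, so the two compounds cannot be ranked against each other. No supporting evidence is available that bears on this step.

As far as these compounds go, whether a longer chain, a carboxylic acid or an amine on this chain would move the number beyond the scatter remains open. From the compounds shown here alone, it is also open whether the same ethyl step would read alike if other parts of the core were changed.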